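Ring Swap on the Chain, Tried on a Second Core

A few compounds are considered here, and "the series" means these few. Any claim that something is new, unique, unknown or untested is made for them only; others in the source may bear on it.

Of the compounds shown here, three have been measured in an assay on LX2 cells for inhibition of COL1A1 promoter (Homo sapiens), read by a luciferase reporter, with a stated time of 24 h, tested at 50 uM; on this read-out lower numbers stand for a weaker effect and higher numbers for a stronger effect at the one concentration tested. Compound 1 `Cc1cc(-n2cc(C(=O)Nc3cc(F)cc(F)c3)c(=O)c3ccc(N(C)C)nc32)ccc1OCCCCCCC[n+]1ccccc1` gives 55%. Compound 2 `Cc1cc(OCCCCCCC[n+]2ccccc2)cc(-n2cc(C(=O)Nc3cc(F)cc(F)c3)c(=O)c3ccc(N(C)C)nc32)c1` gives 61%. Compound 3 `CC[N+]1(CCCCCCCOc2ccc(-n3cc(C(=O)Nc4cc(F)cc(F)c4)c(=O)c4ccc(N(C)C)nc43)cc2C)CCCCC1` gives 53.4%.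

Compound 3 arises from compound 1 by a group of 8 heavy atoms (7 carbon, 1 nitrogen; one six-membered non-aromatic ring with 1 hetero atom) in place of a group of 6 heavy atoms (5 carbon, 1 nitrogen; one six-membered aromatic ring with 1 hetero atom), on a saturated chain carbon, seven bonds along the chain from an oxygen on an aromatic ring, and in this assay that step came to a number 1.6 percentage points lower from compound 1 to compound 3 (within the scatter). Compounds 1 and 2 are built from the same atoms joined differently; the difference between the two cores is not broken down here. Compound 4 `CC[N+]1(CCCCCCCOc2cc(C)cc(-n3cc(C(=O)Nc4cc(F)cc(F)c4)c(=O)c4ccc(N(C)C)nc43)c2)CCCCC1`, not yet measured, arises from compound 2 by a group of 8 heavy atoms (7 carbon, 1 nitrogen; one six-membered non-aromatic ring with 1 hetero atom) in place of a group of 6 heavy atoms (5 carbon, 1 nitrogen; one six-membered aromatic ring with 1 hetero atom), on a saturated chain carbon, seven bonds along the chain from an oxygen on an aromatic ring, the same change at the same place. The step expected from compound 2 to compound 4 in this assay is a number 2 percentage points lower from compound 2 to compound 4 (within the scatter), resting on the earlier step, a number 1.6 percentage points lower from compound 1 to compound 3 (within the scatter). Compound 4 is therefore estimated at 59%, with a likely range from 46% to 72%.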

Compound 4, a percentage reported as inhibition, at one concentration (the size of the read-out at that concentration, not a potency): 86.6%
Compound 4: the middle estimate sits 27.6 percentage points below what was measured; the whole stated range lies below it.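

On the core of compound 2, putting the group with the six-membered non-aromatic ring in place of the group with the six-membered aromatic ring came, in this assay, to a number 25.6 percentage points higher from compound 2 to compound 4 (beyond the scatter). The same change thus did not carry over from one core to the other at the same size: the same change on two cores in this assay, a number 1.6 percentage points lower (within the scatter) from compound 1 to compound 3 and a number 25.6 percentage points higher (beyond the scatter) from compound 2 to compound 4, 27.2 percentage points apart, beyond the scatter of two such steps

This shows that, in these two pairs, the size of the step depends on the core; it does not show why, and two cores give no rule for a third.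

The compounds shown leave open whether a similar dependence on the core would appear with another group at the chain end, such as a trimethylammonium group or a tertiary amine. They also leave open whether it would persist with a shorter or longer chain.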